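Replacing 4-ethoxyphenyl on compound 3

This account rests on a few compounds, and the source may have more. Where it says the series, first, only, none or still open, it means among the compounds named here.

Of the compounds shown here, three have measured numbers so far. In a functional assay on PANC-1 cells (Homo sapiens), read by microscopy, crystal violet staining and transwell migration, with a stated time of 18 h, in the presence of a further agent that is not named here (a higher number here means a weaker inhibitor, a lower number a stronger inhibitor), compound 1 (`COc1ccc(-c2nc(C)nn2-c2cccc(C(=O)NCCCOc3ccccc3)c2)cc1`) gives 3120 nM. In the same test, compound 2 (`COc1ccc(-c2nc(C3CC3)nn2-c2cccc(C(=O)NCCCCc3ccccc3)c2)cc1`) gives 7680 nM. Compound 3 (`CCOc1ccc(-c2nc(CC)nn2-c2cccc(C(=O)NCCCCc3ccccc3)c2)cc1`) gives 16800 nM, the highest of the three numbers, and it is therefore the weakest inhibitor measured. Its gaps to compound 2 and to compound 1 both lie beyond the scatter. Going by the values given here, these three compounds differ in more than one place, so no measured pair isolates a single change.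

Compound 4 (`CCc1nc(-c2ccc(OC)cn2)n(-c2cccc(C(=O)NCCCCc3ccccc3)c2)n1`) departs from compound 3 in one place: 5-methoxypyridin-2-yl in place of 4-ethoxyphenyl on an aromatic carbon. In words, 5-methoxypyridin-2-yl stands in place of 4-ethoxyphenyl on an aromatic carbon of the five-membered aromatic ring with 3 nitrogen. Among the compounds with values here, the data hold no direct precedent for this exchange. Compound 3 sits at the top of the measured range, while compound 2 at 7680 nM and compound 1 at 3120 nM lie lower. In this assay the expectation is therefore no step beyond the scatter, with a slight lean towards a lower number. The estimated change is a 1.5-fold lower number from compound 3 to compound 4 (0.18 log units; within the scatter). For compound 4 the estimated value is 11000 nM, with an expected range of 4000 nM to 30000 nM.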

Compound 4, half-maximal inhibitory concentration: 120 nM
Compound 4: middle estimate off by 92-fold (1.96 log units), on the high side; the whole stated range lies above it.
By their numbers in this assay, from the lowest: compound 4; then compound 1; then compound 2; then compound 3.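

In this assay, 5-methoxypyridin-2-yl in place of 4-ethoxyphenyl gives a 140-fold lower number from compound 3 to compound 4 (2.15 log units; beyond the scatter). Going by these compounds alone, this is the first step that isolates one place, and it shows that the group on this aromatic carbon of the five-membered aromatic ring with 3 nitrogen can move the number far beyond the scatter, with the ethyl group and the 4-phenylbutyl amide held constant. The exchange is still a composite one, as a ring nitrogen enters and methoxy stands where ethoxy stood, taking the group from 9 to 8 heavy atoms and from 1 to 2 hydrogen-bond acceptors, and nothing at hand accounts for the size of the step.

As far as these compounds go, it remains open whether the step follows the ring nitrogen, the methoxy for ethoxy exchange, or only the two together. An ethoxy group on the pyridine ring and a methoxy group on the phenyl ring of compound 3, each with all else unchanged, would separate these, while an amine or a carboxylic acid in place of the methoxy would test how much change the pyridine substituent tolerates.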